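Compound 3 to compound 4: a series at its limit

The compounds below may be only part of what the source reports. "The series", "measured", "known", "first", "only" and "open" are said of these compounds alone.

In an ADME assay on HEK293 cells (Homo sapiens) for cytotoxicity, with a stated time of 72 h (on this read-out lower numbers stand for an effect already at smaller amounts and higher numbers for an effect only at larger amounts of compound), compound 3 `C=C[C@@](C)(/C=C/c1ccc(Nc2cc(F)cc(F)c2)cc1)CCC=C(C)C` gives > 36600 nM as a limit and not as a number. Compound 1 `C=C[C@@](C)(/C=C/c1ccc(OCc2ccccc2)cc1)CCC=C(C)C` gives > 36600 nM as a limit in the same read-out. Compound 2 `C=C[C@@](C)(/C=C/c1ccc(Nc2ccc(F)c(F)c2)cc1)CCC=C(C)C` gives > 36600 nM as a limit as well. The record so far is the limit of > 36600 nM in this assay, at which 3 of the 3 values shown sit, and offers no number by which to rank the compounds.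

Compound 4 `C=C[C@@](C)(/C=C/c1ccc(-c2ccc(Cl)cc2)cc1)CCC=C(C)C` carries 4-chlorophenyl in place of (3,5-difluorophenyl)amino on an aromatic carbon of a six-membered aromatic ring of carbon only, para to a large group, and the counted difference is 4-chlorophenyl in place of (3,5-difluorophenyl)amino on an aromatic carbon for this change.

Within the data shown here, three measured steps bear on it. Two replace the group on that aromatic carbon, a step that the two limits leave unreadable from compound 1 to compound 2 and a step that the two limits leave unreadable from compound 1 to compound 3 in turn. The third changes the fluorine pattern, a step that the two limits leave unreadable from compound 2 to compound 3 in this case. None of the three has a readable size, so no measured size carries over to the new group.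

The expectation rests on compound 3 and its limit > 36600 nM as the starting point. The expected change is a step that the limit leaves unreadable from compound 3 to compound 4 in this assay with no preferred direction and nothing beyond the scatter. Compound 4 is estimated at 40000 nM within an expected range of 18000 nM to 80000 nM and will probably be reported as a limit again.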

Compound 4, half-maximal effective concentration: > 36600 nM
Compound 4 ended at the assay's limit; the forecaster's own chance of this, stated with the estimate: 80%; the middle value is on the limit's open side.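

In this assay, among these compounds, compound 4 gives > 36600 nM, a limit and not a number, so no step between compound 4 and compound 1, compound 2 or compound 3 can be read. The record now stands at: the limit of > 36600 nM in this assay, at which 4 of the 4 values shown sit.

Left open is where compounds 1 to 4 would rank against one another, since none has a numerical value.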